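Compound 4: methoxy in place of hydroxy, tolerance expected

This account rests on a few compounds, and the source may have more. Where it says the series, first, only, none or still open, it means among the compounds named here.

Measured so far in a functional assay on RD cells (Homo sapiens) for inhibition, read by luminescence and ATP content, with a stated time of 72 h; a higher number here means that more compound is tolerated, a lower number that less compound is tolerated:
- compound 1 `CCc1nc(-c2cnc3ccc(-c4cccc(N)c4)cc3c2)no1`: > 7400 nM, a limit of the assay
- compound 2 `CCc1nc(-c2cnc3ccc(-c4ccccc4)cc3c2)no1`: > 7400 nM, a limit of the assay
- compound 3 `CCc1nc(-c2cnc3ccc(-c4ccc(O)cc4)cc3c2)no1`: > 2500 nM, a limit of the assay

Compound 3 stands only at a limit in this assay; the two other values shown are limits as well the limit of > 2500 nM in this assay, at which 1 of the 3 values shown sits (the limit of > 7400 nM in this assay, at which 2 of the 3 values shown sit). For the measured compounds named here, none of the measured steps can be read: a step that the two limits leave unreadable from compound 1 to compound 2, a step that the two limits leave unreadable from compound 1 to compound 3, a step that the two limits leave unreadable from compound 2 to compound 3.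

Compound 4 `CCc1nc(-c2cnc3ccc(-c4ccc(OC)cc4)cc3c2)no1` differs from compound 3 by methyl in place of hydrogen on an oxygen on an aromatic ring. Going by the values given here, no measured step bears readably on this change, and every compound so far is tolerated up to its limit. Compound 4 is therefore expected to sit at a limit too, with the step from compound 3 to compound 4 estimated as a step that the limit leaves unreadable from compound 3 to compound 4. The estimate for compound 4 in this assay is 7400 nM, expected between 2500 nM and 30000 nM.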

Compound 4, half-maximal cytotoxic concentration: > 2500 nM
Compound 4: a limit, no number; the forecaster's own chance of this, stated with the estimate: 85%; the middle value does not contradict the limit.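

In this assay compound 4 gives > 2500 nM, which is a limit, so the steps to it from compound 1, compound 2 and compound 3 cannot be read. The compounds shown leave open where the half-maximal cytotoxic concentration of any of them actually lies.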